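The source may report more compounds than this note shows. Statements on the series, on what has been measured and on what is new or still open speak of the compounds shown alone.

Four sugar-like compounds appear here. Compound 1 `O[C@@H]1[C@@H](OCc2ccccc2)[C@H](OCc2ccccc2)[C@@H](COCc2ccccc2)O[C@H]1CC1CCCCC1` gives 4100 nM in a functional assay on HL-60 cells (Homo sapiens) for antiproliferative activity, read by MTT assay (a higher number here means a weaker inhibitor, a lower number a stronger inhibitor), the lowest of the two numbers measured. For the measured compounds named here, compound 2 `c1ccc(COC[C@H]2O[C@@H]3C[C@@H]3[C@@H](OCc3ccccc3)[C@@H]2OCc2ccccc2)cc1` gives 38500 nM in this assay, a gap beyond the usual scatter; no direct step between these two has been worked out, so only their values can be set side by side. Compound 3 `CCC[C@@H]1O[C@H](CO)[C@@H](O)[C@H](O)[C@H]1O` was reported as "not active" (no number reported) in this assay, without a number.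

Compound 4 `O[C@H]1CO[C@H](COCc2ccccc2)[C@@H](OCc2ccccc2)[C@@H]1OCc1ccccc1` has not yet been measured. It differs from compound 1 in one place: hydrogen in place of cyclohexylmethyl on a saturated ring carbon. Going by the values given here, no measured pair follows this exact change, so the expectation rests on the values shown. Compound 2, which likewise carries no cyclohexylmethyl, gives 38500 nM in this assay, and that leans the guess towards weaker inhibition. The step from compound 1 is expected to be of moderate size in the weaker direction, a 3.7-fold higher number from compound 1 to compound 4 (0.56 log units; beyond the scatter). Compound 4 is therefore estimated at 15000 nM in this assay, with a range expected from 5000 nM to 50000 nM.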

Compound 4, half-maximal inhibitory concentration: "not active" (no number reported)
The entry for compound 4 holds no number, so the estimate cannot be set against anything.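

For the compounds shown here, compound 4 has no number in this assay, so no step from compound 1 to compound 4 can be read, and no evidence here bears on this result. The compounds shown leave open how much swapping cyclohexylmethyl for hydrogen changes activity in this assay.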